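Tetrahydropyridinyl in place of dimethylpiperidinyl on the shared core

The compounds below may be only part of what the source reports. "The series", "measured", "known", "first", "only" and "open" are said of these compounds alone.

Working notes on the series. The read-out is an assay on CHO-K1 cells for antagonist activity at adenosine receptor A1 (Homo sapiens), read by a beta-galactosidase reporter, with stated times of 15 min and 6 h; on this read-out higher numbers stand for weaker inhibition and lower numbers for stronger inhibition. Compound 2 `C[C@@H]1CCC[C@H](C)N1Cc1cc2c(N)nc(-c3cccc(C#N)c3)nc2s1` gives 460 nM in this assay, the highest of the two numbers recorded so far. Compound 1 `Nc1nc(-c2ccc(Cl)o2)nc2sc(CN3CC=CCC3)cc12` gives 190 nM in this assay, a lower number than compound 2, and the gap between the two lies beyond the usual scatter. Among the compounds with values here, compound 1 and compound 2 differ in more than one place, so no single step between measured compounds is available to anchor a change.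

Compound 3 `N#Cc1cccc(-c2nc(N)c3cc(CN4CC=CCC4)sc3n2)c1` has not yet been measured. It differs from compound 2 in one place: a group of 6 heavy atoms (5 carbon, 1 nitrogen; one six-membered non-aromatic ring with 1 hetero atom) in place of a group of 8 heavy atoms (7 carbon, 1 nitrogen; one six-membered non-aromatic ring with 1 hetero atom), on a saturated chain carbon bound to an aromatic carbon. Within the data shown here, no measured pair shows this change on its own, so its size is uncertain. Among the measured compounds shown here, the remainder of compound 3 is shared with compound 2, and the entering ring is the one carried by compound 1. The step of a 1.5-fold lower number from compound 2 to compound 3 (0.19 log units; within the scatter) is estimated to be small, towards a lower number, and may well fall within the scatter. Compound 3 is expected to give about 300 nM in this assay, within a range from 100 nM to 900 nM.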

Compound 3, inhibition constant: 210 nM
Beside the measured number, compound 3's estimate is 1.4-fold (0.15 log units) above it; low and high end bracket the measured number.
By their numbers in this assay, from the lowest: compounds 1 and 3 (each within the scatter of the next); then compound 2.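

Within the data shown here, on the saturated chain carbon bound to an aromatic carbon, the shared core with 3-cyanophenyl now gives the first single-place reading of this position in this assay: tetrahydropyridinyl in place of 2,6-dimethylpiperidin-1-yl gives a 2.2-fold lower number from compound 2 to compound 3 (0.34 log units; beyond the scatter) and so a modest step towards stronger inhibition. With the tetrahydropyridinyl group kept, 3-cyanophenyl in place of 5-chlorofuran-2-yl on an aromatic carbon gives a 1.1-fold higher number from compound 1 to compound 3 (0.04 log units; within the scatter) and so this read-out does not separate the two aromatic groups in this pair. Nothing measured bears on what lies behind either step.

The ring change removes the two methyl groups and adds the double bond together, and the compounds shown do not separate these two differences; a plain piperidin-1-yl group on the same carbon would do so. Also open, going by these compounds, are whether the step carries over to the 5-chlorofuran-2-yl series and how a morpholine ring or an open-chain diethylamino group reads at this position.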